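Compound 4 and a missing cytotoxicity baseline

A few compounds are considered here, and "the series" means these few. Any claim that something is new, unique, unknown or untested is made for them only; others in the source may bear on it.

Three compounds have entries in this small set, and only one of them carries a number. In an ADME assay on Vero cells (Chlorocebus sabaeus) for cytotoxicity, read by resazurin assay, with a stated time of 3 days (a lower number here means that less compound is tolerated, a higher number that more compound is tolerated), compound 2 (`Nc1nc(CSc2nc3ccccc3[nH]2)nc(Nc2ccccc2)n1`) has the entry "not determined" (no result reported) and so offers no single number as a baseline. Compound 1 (`Cc1ccc2[nH]c(SCc3nc(N)nc(Nc4ccccc4)n3)nc2c1`) is in the same position, with its entry in this assay reading "not determined" (no result reported) as well. Going by the values given here, the only number comes from compound 3 (`COc1ccc(Nc2nc(N)nc(CSc3nnc(-c4ccncc4)n3-c3ccccc3)n2)cc1`), which gives 1500 ug/mL in this assay on this measure. Among the compounds with values here, no two measured compounds differ in just one place, so the data show no step to borrow.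

Compound 4 (`Nc1nc(CSc2nc3ccccc3[nH]2)nc(Nc2ccc(Cl)cc2)n1`) has yet to be measured. The structural change is chloro in place of hydrogen on an aromatic carbon with chloro in place of hydrogen on an aromatic carbon, para to a large group. Within the data shown here, with no measured step as a guide and no number for compound 2 to start from, a modest move towards less compound being tolerated is expected, of a size that may not exceed the usual scatter. The scale of the expectation rests only on compound 3 at 1500 ug/mL in a structure of its own, so the range is kept wide. In this assay compound 4 is estimated at 400 ug/mL with an expected range of 60 ug/mL to 2000 ug/mL around that figure.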

Compound 4, half-maximal cytotoxic concentration: 1500 ug/mL
Compound 4: the middle estimate sits 3.8-fold (0.57 log units) below what was measured, and the stated range covers the measured number.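

In this assay, going by these compounds alone, compound 2 carries the entry "not determined" (no result reported), so no step from it to compound 4 can be read. The compounds shown leave open what the change from phenyl to 4-chlorophenyl does in this assay. No further data here bear on the result for compound 4.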